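Shortening the Link to the Oxazolidinedione Ring

The compounds below may be only part of what the source reports. "The series", "measured", "known", "first", "only" and "open" are said of these compounds alone.

Measured so far:
Compound 1, `CC(C)[C@@H](C[C@H]1SC(=O)NC1=O)c1ccc(-c2ccc3cccc(F)c3c2)[nH]c1=O`, gives 6 nM
Compound 2, `CC(C)[C@H](C[C@H]1OC(=O)NC1=O)c1ccc(-c2ccc3cccc(F)c3c2)[nH]c1=O`, gives 6 nM
Compound 3, `CC(C)(/C=C1\OC(=O)NC1=O)c1ccc(-c2ccc3cccc(F)c3c2)[nH]c1=O`, gives 38 nM

All three share a core and were tested in an assay on membranes from Chem-1 cells for displacement of a labelled ligand from prostaglandin E2 receptor EP3 subtype (Homo sapiens), read by scintillation counting, with a stated time of 2 h; on this read-out higher numbers stand for weaker inhibition and lower numbers for stronger inhibition. Compound 2 stands level with compound 1 at the digits shown, and together they give the lowest numbers of the three. Compound 3 gives a higher number, and its gap to compound 2 lies beyond the usual scatter of repeated measurements.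

The next compound is compound 4, `CC(C)[C@@H](c1ccc(-c2ccc3cccc(F)c3c2)[nH]c1=O)[C@H]1OC(=O)NC1=O`. It differs from compound 2 in one place:

2,4-dioxo-1,3-oxazolidin-5-yl in place of (2,4-dioxo-1,3-oxazolidin-5-yl)methyl on a saturated chain carbon bound to an aromatic carbon and a saturated chain carbon

The ring that carries the hydrogen-bond donor and acceptors thus moves one chain carbon closer to the core. Among the measured compounds shown here, no pair of measured compounds differs in exactly this way, so the size of the step is not anchored by a measured step. The nearest hint is compound 3, where a different link to the same ring goes with a higher number than in compound 2. Since the measured set does not contain this change, a loss is expected, and from compound 2 to compound 4 a step of a 5.0-fold higher number from compound 2 to compound 4 (0.70 log units; beyond the scatter) is estimated. Compound 4 is expected to give 30 nM, with a range from 6 nM to 200 nM.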

Compound 4, inhibition constant: 27 nM
For compound 4 the middle estimate is 1.1-fold (0.05 log units) above the measured one; low and high end bracket the measured number.
By their numbers in this assay, from the lowest: compounds 1 and 2 (each within the scatter of the next); then compounds 4 and 3 (each within the scatter of the next).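

In this assay, among the compounds shown here, the shortening gives a 4.5-fold higher number from compound 2 to compound 4 (0.65 log units; beyond the scatter), which is the first measured step at this position and shows that the length of the link alone can change the result. The 2,4-dioxo-1,3-oxazolidin-5-yl ring itself stays the same, with the same hydrogen-bond donor and acceptor counts. The leaving and entering groups differ in the methyl link on the saturated chain carbon. The data at hand offer no measurement that explains why the shorter link goes with the higher number.

The compounds shown leave open whether a longer chain carrying the same ring would lower the number, raise it or leave it within the scatter, so only one direction of change in link length is covered. They also leave open whether the ring is needed at this position at all, which a carboxylic acid on the same saturated chain carbon would test, and whether shortening the link has a similar effect on the sulfur-containing ring of compound 1.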